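Methoxy addition on a biaryl amide: an expected small step

The compounds below may be only part of what the source reports. "The series", "measured", "known", "first", "only" and "open" are said of these compounds alone.

Of the compounds shown here, two have so far been measured in an assay on isolated protein for inhibition of N-lysine methyltransferase SMYD2 (Homo sapiens); a higher number here means a weaker inhibitor, a lower number a stronger inhibitor. Compound 1 (`COc1ccccc1-c1cc(C(=O)NCCCN2CCCC2)c2cn[nH]c2n1`) and compound 2 (`Cc1ccccc1-c1cccc(C(=O)NCCCN2CCCC2)c1`) share the amide-linked propyl chain ending in a pyrrolidine but differ in their central core. In this assay compound 1 gives 14500 nM, and in this assay compound 2 gives 17400 nM. These two numbers lie within the scatter of each other, so compound 2 cannot be told apart from compound 1 on the numbers shown; both sit at the weak end of what such an assay resolves. Within the data shown here, no pair of measured compounds differs in only one place, so no measured step is available as a guide.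

Compound 3 (`COc1cc(C(=O)NCCCN2CCCC2)cc(-c2ccccc2C)c1`) is the next compound to be examined. It differs from compound 2 by methoxy in place of hydrogen on an aromatic carbon. Among the measured compounds shown here, nothing among the measured compounds shows what such a change does here. The step from compound 2 to compound 3 is therefore expected to be small, a 1.2-fold lower number from compound 2 to compound 3 (0.06 log units; within the scatter), and within the scatter in either direction. Compound 3 is accordingly estimated at 15000 nM, with a range from 6000 nM to 40000 nM.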

Compound 3, half-maximal inhibitory concentration: 22100 nM
Estimate against measurement, compound 3: 1.5-fold (0.17 log units) below, and the stated range covers the measured number.
By their numbers in this assay, from the lowest: compounds 1, 2 and 3 (each within the scatter of the next).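

Among these compounds, this result gives the first measured step between compounds that differ in one place in this assay: with methoxy in place of hydrogen on an aromatic carbon, meta to a 2-methylphenyl group, the step is a 1.3-fold higher number from compound 2 to compound 3 (0.10 log units; within the scatter) and compound 2 and compound 3 cannot be told apart on these numbers. At this place on the six-membered aromatic ring of carbon only, a group of 2 heavy atoms carrying 1 hydrogen-bond acceptor therefore stands in for hydrogen with no change that the assay can resolve, although this single step speaks only for methoxy and only for this place. Nothing at hand bears on why the step is this size.

The compounds shown leave open whether another group at this same place, such as an amine, a carboxylic acid or a longer chain like ethoxy, would move the number beyond the scatter. They also leave open whether methoxy on an aromatic carbon would give a similar step on the core of compound 1, or with a group other than 2-methylphenyl on the ring.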